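One More Methyl on the Amine Chain

The source may hold more compounds than are shown below. What is called first, only, known or untested is meant among the compounds shown, and "the series" means these compounds.

In a functional assay on the whole organism with Rattus norvegicus as the target (a higher number here means that more compound is needed for the effect, a lower number that less compound is needed), compound 1 `CCOC(=O)C(=O)Nc1cccc(N(C)C)c1C#N` gives 0.2 mg/kg in this test, while compound 2 `CCOC(=O)C(=O)Nc1cccc(N(C)CC)c1C#N` gives 0.3 mg/kg in the same test. Among the measured compounds shown here, compound 2 therefore stands within the usual scatter of compound 1, the only other compound measured, and the two cannot be ranked. Compound 3 `CCOC(=O)C(=O)Nc1cccc(N(C)C(C)C)c1C#N` extends compound 2 by one further small change: methyl in place of hydrogen on a saturated chain carbon bound to a nitrogen on an aromatic ring and a saturated chain carbon which turns ethyl(methyl)amino into isopropyl(methyl)amino. For the measured compounds named here, only one measured step bears on this, namely a 1.5-fold higher number from compound 1 to compound 2 (0.18 log units; within the scatter) where a methyl also replaced a hydrogen on a saturated chain carbon bound to a nitrogen on an aromatic ring. A single small step is thin evidence, so little movement is expected. In this assay the expected result is a 1.2-fold higher number from compound 2 to compound 3 (0.07 log units; within the scatter) and so nothing clearly beyond the scatter. For compound 3 the estimate is 0.35 mg/kg with an expected range from 0.15 mg/kg to 0.9 mg/kg overall.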

Compound 3, dose for half-maximal effect: 0.3 mg/kg
Beside the measured number, compound 3's estimate is 1.2-fold (0.07 log units) above it; the range from low to high includes it.
By their numbers in this assay, from the lowest: compounds 1, 2 and 3 (each within the scatter of the next).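

In this assay, adding a methyl to the chain carbon gives no change at the digits printed from compound 2 to compound 3 (within the scatter), so turning ethyl(methyl)amino into isopropyl(methyl)amino produces no readable difference. Replacing methyl with isopropyl on the nitrogen gives a 1.5-fold higher number from compound 1 to compound 3 (0.18 log units; within the scatter), so all three groups at this position, including the branched isopropyl, remain within the scatter of one another. Nothing available here explains this flat result.

The compounds shown leave open whether a longer chain such as n-butyl, or a bulkier group such as tert-butyl or cyclohexyl, on this nitrogen would move the dose beyond the scatter. They also leave open what an amine carrying a hydrogen on the nitrogen in place of one of its carbon groups would do.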